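The source may report more compounds than this note shows. Statements on the series, on what has been measured and on what is new or still open speak of the compounds shown alone.

Measured in a functional assay on HepG2 cells (Homo sapiens) for inhibition, read by MTT assay, with a stated time of 72 h; on this read-out higher numbers stand for weaker inhibition and lower numbers for stronger inhibition:

- Compound 1 `CC(C)c1ccc(NC(=O)C2CCN(C/C=C/c3ccccc3)CC2)cc1`: 12200 nM
- Compound 2 `O=C(Nc1ccccn1)C1CCN(C/C=C/c2ccccc2)CC1`: 51100 nM

Of these two compounds, compound 2 has the higher number, 51100 nM, and so the weaker inhibition. Its nearest neighbour is compound 1, at 12200 nM.

Compound 3 `O=C(Nc1nccs1)C1CCN(C/C=C/c2ccccc2)CC1` has not yet been measured. It differs from compound 2 by one exchange: 1,3-thiazol-2-yl in place of pyridin-2-yl on an amide-type nitrogen. In words, 1,3-thiazol-2-yl stands in place of pyridin-2-yl on an amide-type nitrogen.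

Going by the values given here, only one measured step bears on this exchange. It is a 4.2-fold higher number from compound 1 to compound 2 (0.62 log units; beyond the scatter), and it placed pyridin-2-yl where 4-isopropylphenyl had been, on the same kind of nitrogen. Among the compounds with values here, that modest step replaced a different group, and no measured compound carries 1,3-thiazol-2-yl, so the step gives no direction for the new exchange. It serves only as a rough guide to size. A smaller change is expected here, one that stays within the scatter, and the estimate is a 1.2-fold lower number from compound 2 to compound 3 (0.09 log units; within the scatter). In this assay, compound 3 is expected at 42000 nM, with an estimated range of 16000 nM to 100000 nM.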

Compound 3, half-maximal inhibitory concentration: 22400 nM
For compound 3 the middle estimate is 1.9-fold (0.27 log units) above the measured one; low and high end bracket the measured number.
By their numbers in this assay, from the lowest: compounds 1 and 3 (each within the scatter of the next); then compound 2.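

In this assay, the group on the amide-type nitrogen now separates two heteroaromatic rings from each other: with the six-membered pyridin-2-yl leaving and the five-membered 1,3-thiazol-2-yl entering, the change is a 2.3-fold lower number from compound 2 to compound 3 (0.36 log units; beyond the scatter). The comparison with the 4-isopropylphenyl compound reads a 1.8-fold higher number from compound 1 to compound 3 (0.26 log units; within the scatter), so exchanging 4-isopropylphenyl for a ring with hetero atoms does not always move the number beyond the scatter, as the earlier step alone might have suggested; compound 2 moves beyond it, while compound 3 does not. Nothing available gives a reason for either step.

The compounds shown leave open whether a plain phenyl ring on this nitrogen would fall with the 4-isopropylphenyl and 1,3-thiazol-2-yl compounds or with the pyridin-2-yl compound, and what a methyl group or an amine on the 1,3-thiazol-2-yl ring would do to the number. They also leave open whether these steps hold on the shared core outside this assay.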